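The source may report more compounds than this note shows. Statements on the series, on what has been measured and on what is new or still open speak of the compounds shown alone.

Measured so far in an ADME assay on isolated protein for inhibition of cytochrome P450 2B6 (Homo sapiens), read by HPLC; on this read-out lower numbers stand for stronger inhibition and higher numbers for weaker inhibition:
- compound 1 `Cc1c(Cc2ccc(C(F)(F)F)nc2)c[nH]c1C(=O)NC(C)c1cnn(C)c1`: > 20000 nM
- compound 2 `Cc1c(C2(c3ccc(C(F)(F)F)nc3)CC2)c[nH]c1C(=O)NC(C)c1c[nH]cn1`: "not determined" (no result reported)

Compound 1 gives no number in this assay, only a limit of the assay, > 20000 nM. For compound 2 this assay reports no result, "not determined" (no result reported), so compound 1 is the only entry with any read-out, and it sits at the limit of > 20000 nM in this assay, at which 1 of the 2 values shown sits. Within the data shown here, with one limit and one blank there is no step between measured compounds, and nothing says how far this kind of change moves the half-maximal inhibitory concentration.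

Compound 3 `Cc1c(Cc2ccc(C(F)(F)F)nc2)c[nH]c1C(=O)NC(C)c1cn[nH]c1` differs from compound 1 by hydrogen in place of methyl on an aromatic nitrogen. Since compound 1 already sits at the limit, the step to compound 3 in this assay is expected to stay within the scatter, with no direction beyond it, and the outcome is most likely another limit rather than a number. Compound 3 is therefore expected at 30000 nM, with a range from 10000 nM to 100000 nM. The expected step that the limit leaves unreadable from compound 1 to compound 3 is small.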

Compound 3, half-maximal inhibitory concentration in the cytochrome P450 2B6 assay: > 20000 nM
Compound 3: only a limit was reported; the forecaster's own chance of this, stated with the estimate: 80%; the middle value is on the limit's open side.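

In the cytochrome P450 2B6 assay compound 1 and compound 3 both stop at a limit of the assay, so no step can be read between these two compounds. In a physicochemical assay for solubility, in simulated intestinal fluid, with a stated time of 5 h, at pH 5.8 (a higher number here means a more soluble compound, a lower number a less soluble compound), compound 1 gives 158 ug/mL and compound 3 gives 81 ug/mL with the two within the usual scatter. Still open, as far as these compounds go, is whether any change to the core of compound 1 gives a number in the cytochrome P450 2B6 assay rather than a limit.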